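The compounds below may be only part of what the source reports. "The series", "measured", "known", "first", "only" and "open" are said of these compounds alone.

Working notes on the series. Compound 1 `CCOC(=O)C1=C(Nc2ccccc2)S/C(=C\c2ccccc2)C1=O` gives 20.3% in a functional assay on JAR cells (Homo sapiens) for inhibition, read by MTT assay, with a stated time of 72 h, tested at 10 uM; on this read-out higher numbers stand for more inhibition at the one concentration tested (going by the name of the read-out) and lower numbers for less inhibition. For the measured compounds named here, compound 2 `CCOC(=O)C1=C(Nc2ccccc2)S/C(=C\c2ccc(O)c(O)c2)C1=O` gives 48.7% in this assay and stands highest of the two numbers so far, with the rise a number 28.4 percentage points higher from compound 1 to compound 2 (beyond the scatter) lying beyond the scatter. Compound 3 `CCOC(=O)C1=C(Nc2ccccc2)S/C(=C\c2ccc(OC)cc2)C1=O` is not yet measured; it differs from compound 2 by 4-methoxyphenyl in place of 3,4-dihydroxyphenyl on a double-bonded chain carbon bound to a double-bonded ring carbon. Going by the values given here, the only step bearing on this is the one from compound 1 to compound 2, a modest rise; the move to compound 3 runs partly back toward compound 1, so a fall a number 20.7 percentage points lower from compound 2 to compound 3 (beyond the scatter) is expected. For compound 3 the expected value is 28%, with a range of 10% to 50%.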

Compound 3, a percentage reported as inhibition, at one concentration (the size of the read-out at that concentration, not a potency): 32.9%
Compound 3: middle estimate off by 4.9 percentage points, on the low side, and the stated range covers the measured number.
By their numbers in this assay, from the lowest: compound 1; then compound 3; then compound 2.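

In this assay a rise over the unsubstituted phenyl does not depend on the 3,4-dihydroxyphenyl group: methoxy in place of hydrogen on an aromatic carbon gives a number 12.6 percentage points higher from compound 1 to compound 3 (beyond the scatter). Even so, 4-methoxyphenyl in place of 3,4-dihydroxyphenyl gives a number 15.8 percentage points lower from compound 2 to compound 3 (beyond the scatter), so compound 3, with 0 hydrogen-bond donors in this group, sits between the other two. No evidence on the cause of either step is at hand. From the compounds shown here alone, whether one hydroxy group would match the pair in compound 2 remains open. So does the outcome with an amine or a carboxylic acid on this aromatic ring.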